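The source may report more compounds than this note shows. Statements on the series, on what has been measured and on what is new or still open speak of the compounds shown alone.

Compound 2 `COc1cc(Cl)nc(NC(=S)NC(=O)c2c(-c3ccc(Cl)cc3Cl)noc2C)n1` and compound 1 `COc1cc(SC)nc(NC(=S)NC(=O)c2c(-c3ccc(Cl)cc3Cl)noc2C)n1` share one core and differ in a single place: methylsulfanyl in place of chloro on an aromatic carbon. In a functional assay on the whole organism for inhibition, with Brassica napus as the target, with a stated time of 72 h, tested at 10 mg/L (a lower number here means less inhibition of growth, a higher number more inhibition of growth at the concentration tested), compound 2 gives 30.7%, while compound 1 gives 18.7%, so that a number 12 percentage points lower from compound 2 to compound 1 (beyond the scatter). Compound 3 `COc1cc(Cl)nc2n/c(=N/C(=O)c3c(-c4ccc(Cl)cc4Cl)noc3C)sn12` carries a different core; the difference between the two cores is not broken down here. In this assay compound 3 gives 28.6%, a value within the scatter of compound 2. Compound 4 `COc1cc(SC)nc2n/c(=N/C(=O)c3c(-c4ccc(Cl)cc4Cl)noc3C)sn12` has not yet been measured and differs from compound 3 thus: methylsulfanyl in place of chloro on an aromatic carbon. This is the same kind of change as before, though here the place is part of a fused or bridged system of two rings, meta to a fused ring and para to a fused ring, where earlier it was meta to a large group. Resting on the measured step of a number 12 percentage points lower from compound 2 to compound 1 (beyond the scatter), a step of similar size is expected, namely a number 10.6 percentage points lower from compound 3 to compound 4 (beyond the scatter). Compound 4 is accordingly estimated at 18%, likely between 8% and 30%.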

Compound 4, percent growth inhibition at one concentration: 27.4%
Compound 4: the middle estimate sits 9.4 percentage points below what was measured; the range from low to high includes it.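

In this assay, methylsulfanyl in place of chloro on the fused core gives a number 1.2 percentage points lower from compound 3 to compound 4 (within the scatter). Set beside the earlier step on the other core, the two cannot be told apart: the same change on two cores in this assay, a number 12 percentage points lower (beyond the scatter) from compound 2 to compound 1 and a number 1.2 percentage points lower (within the scatter) from compound 3 to compound 4, 10.8 percentage points apart, within the scatter of two such steps. This does not show that the change behaves differently on the two cores, but nor does it establish that the step carries over, as each core offers a single pair, tested at one concentration in one assay.

The compounds shown leave open how an amine or an ethoxy group would compare with chloro and methylsulfanyl at this place. They also leave open whether a longer sulfur-linked chain would give similar steps on both cores.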